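Sulfur for Oxygen: Compound 4 Against Three Limits

The compounds below may be only part of what the source reports. "The series", "measured", "known", "first", "only" and "open" are said of these compounds alone.

Compounds measured so far:
compound 1 `CCOC(=O)[C@H](CCC(=O)O)NC(=O)c1ccc(CNc2nc3cc(N)cc(N)c3nc2-c2ccccc2)cc1` — < 100000 nM
compound 2 `Nc1cc(N)c2nc(-c3ccccc3)c(NCc3ccc(F)cc3)nc2c1` — < 100000 nM
compound 3 `Nc1cc(N)c2nc(-c3ccccc3)c(Oc3ccc(F)cc3)nc2c1` — < 100000 nM

In a functional assay on SNB-75 cells (Homo sapiens) for inhibition, read by sulforhodamine B assay, with a stated time of 48 h (a lower number here means that less compound is tolerated, a higher number that more compound is tolerated), compound 1 is reported only as a limit, < 100000 nM. Compound 2 likewise gives a limit, < 100000 nM. Compound 3 too is known only as a limit, < 100000 nM. For the measured compounds named here, the single step between neighbours, a step that the two limits leave unreadable from compound 2 to compound 3, cannot be read. Compound 3 thus stands at the same point as the other two, (the limit of < 100000 nM in this assay, at which 3 of the 3 values shown sit).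

Compound 4 `Nc1cc(N)c2nc(-c3ccccc3)c(Sc3ccc(F)cc3)nc2c1` differs from compound 3 by (4-fluorophenyl)sulfanyl in place of 4-fluorophenoxy on an aromatic carbon. Going by the values given here, no measured step reaches this change, since the one available step is unreadable. Compound 4 is therefore expected to land again at the limit, with an at least 1.5-fold higher number from compound 3 to compound 4 (0.17 log units; that floor lies within the scatter) anticipated as no step beyond the scatter. The estimate for compound 4 is 150000 nM, between 60000 nM and 400000 nM.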

Compound 4, concentration lethal to 50% of the cells: < 100000 nM
Compound 4 ended at the assay's limit (the forecaster's own chance of this, stated with the estimate: 85%); middle value at least 1.5-fold (0.17 log units) from the limit.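

The steps from compound 3 to compound 4 and from compound 2 to compound 4 cannot be read, since compound 4 too gives only a limit: the limit of < 100000 nM in this assay, at which 4 of the 4 values shown sit.

The compounds shown leave open where each truly lies in this assay, and whether (4-fluorobenzyl)amino, 4-fluorophenoxy and (4-fluorophenyl)sulfanyl differ at all.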